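Swapping 5-methylfuran-2-yl for pyridin-2-yl in compound 3

The source may hold more compounds than are shown below. What is called first, only, known or untested is meant among the compounds shown, and "the series" means these compounds.

Measured so far in a functional assay on HeLa cells (Homo sapiens) for cytotoxicity, read by ELISA, with a stated time of 4 days; a higher number here means a weaker inhibitor, a lower number a stronger inhibitor:
- compound 1 `Cc1ccsc1-c1cc(-c2ccco2)cc(-c2ccccc2Cl)n1` gives 24000 nM
- compound 2 `Cc1ccsc1-c1cc(-c2ccoc2)cc(-c2ccco2)n1` gives 30500 nM
- compound 3 `Cc1ccc(-c2cc(-c3ccoc3)cc(-c3ccc(Cl)s3)n2)o1` gives 26500 nM

These three numbers all lie within the usual scatter of one another, so compound 3 stands level with the other two and they cannot be ranked. Compound 4 `Clc1ccc(-c2cc(-c3ccoc3)cc(-c3ccccn3)n2)s1` has pyridin-2-yl in place of 5-methylfuran-2-yl on an aromatic carbon. Going by the values given here, no measured pair differs in one place only, so no direct step guides the expectation. Still, compound 1 at 24000 nM and compound 2 at 30500 nM carry other groups than compound 3 and stay within the scatter of it, so no change beyond the scatter is expected in this assay. None of the three carries pyridin-2-yl, so the range is kept wide. The expected change is a 1.3-fold lower number from compound 3 to compound 4 (0.12 log units; within the scatter). For compound 4 the estimate is 20000 nM, with an expected range of 6000 nM to 50000 nM.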

Compound 4, half-maximal inhibitory concentration: 21600 nM
Compound 4: the middle estimate sits 1.1-fold (0.03 log units) below what was measured; low and high end bracket the measured number.
By their numbers in this assay, from the lowest: compounds 4, 1, 3 and 2 (each within the scatter of the next).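

In this assay, going by these compounds alone, the first step that changes one place only is a 1.2-fold lower number from compound 3 to compound 4 (0.09 log units; within the scatter) and it shows that, next to the ring nitrogen, a six-membered aromatic ring can replace a five-membered one without a change beyond the scatter. Nothing available explains this result. Still open, as far as these compounds go, is whether an amine or a carboxylic acid on this carbon would move the number beyond the scatter. Also open, from the compounds shown here alone, is whether replacing the 5-chlorothiophen-2-yl or furan-3-yl group would do so.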